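The compounds below may be only part of what the source reports. "The series", "measured", "known", "first", "only" and "open" are said of these compounds alone.

Measured so far:
compound 1 `CN(C)CCn1cnnc1-c1cc(Oc2ccc(NC(=O)N/N=C/c3ccc(F)cc3Cl)cc2F)ccn1`: 1210 nM
compound 2 `CN(C)CCn1cnnc1-c1cc(Oc2ccc(NC(=O)N/N=C/c3ccc(Cl)cc3)cc2F)ccn1`: 1370 nM
compound 3 `CN(C)CCn1cnnc1-c1cc(Oc2ccc(NC(=O)N/N=C/c3ccc(O)c(Br)c3)cc2F)ccn1`: 12400 nM

In a functional assay on U-87MG ATCC cells (Homo sapiens) for cytotoxicity, read by MTT assay, with a stated time of 72 h (on this read-out lower numbers stand for stronger inhibition and higher numbers for weaker inhibition), compound 1 gives the lowest of the three numbers, though compound 2 lies within the scatter of it (a 1.1-fold higher number from compound 1 to compound 2 (0.05 log units; within the scatter)), while compound 3 sits well apart (a 10-fold higher number from compound 1 to compound 3 (1.01 log units; beyond the scatter)). Compound 4 `CN(C)CCn1cnnc1-c1cc(Oc2ccc(NC(=O)N/N=C/c3c(O)ccc4ccccc34)cc2F)ccn1` has not been measured. Relative to compound 1 it carries 2-hydroxynaphthalen-1-yl in place of 2-chloro-4-fluorophenyl on a carbon with a double bond to nitrogen.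

Among the compounds with values here, two measured steps bear on this. Exchanging halogen patterns on the aryl group leaves the number essentially unchanged (a 1.1-fold higher number from compound 1 to compound 2 (0.05 log units; within the scatter)). Bringing a hydrogen-bond donor and acceptor onto that aryl group, as in compound 3, raises the number markedly (a 10-fold higher number from compound 1 to compound 3 (1.01 log units; beyond the scatter), and likewise a 9.1-fold higher number from compound 2 to compound 3 (0.96 log units; beyond the scatter)). The entering group of compound 4 also brings a hydrogen-bond donor and acceptor, but additionally a second six-membered aromatic ring, for which no measured comparison exists. The expectation is therefore a rise in this assay of intermediate size, a 3.3-fold higher number from compound 1 to compound 4 (0.52 log units; beyond the scatter). Compound 4 is estimated at 4000 nM, with a range from 1500 nM to 12000 nM.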

Compound 4, half-maximal inhibitory concentration: 620 nM
Compound 4: the middle estimate sits 6.5-fold (0.81 log units) above what was measured; measured number outside the range, below it.
By their numbers in this assay, from the lowest: compounds 4, 1 and 2 (each within the scatter of the next, the first and the last beyond it); then compound 3.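

In this assay, a hydroxyl on the aryl group does not by itself bring the high number seen for compound 3, since 2-hydroxynaphthalen-1-yl at this position gives a 20-fold lower number from compound 3 to compound 4 (1.30 log units; beyond the scatter). The same group also separates from 4-chlorophenyl, with a 2.2-fold lower number from compound 2 to compound 4 (0.34 log units; beyond the scatter), but not from 2-chloro-4-fluorophenyl, with a 2.0-fold lower number from compound 1 to compound 4 (0.29 log units; within the scatter), so this position accepts the second aromatic ring with no loss against either halogenated phenyl group. Nothing available accounts for these differences.

The hydroxyl and the second ring enter together, so their separate contributions remain unresolved. Also open, as far as these compounds go, is how naphthalen-1-yl without the hydroxyl, or 2-aminonaphthalen-1-yl with an amine in its place, would read at this carbon.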